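A Cyclopentyl Swap at the Tolerance Limit

A few compounds are considered here, and "the series" means these few. Any claim that something is new, unique, unknown or untested is made for them only; others in the source may bear on it.

Of the compounds shown here, three have been read in an ADME assay on MT4 cells (Homo sapiens) for activation, read by MTT assay; a higher number here means that more compound is tolerated, a lower number that less compound is tolerated. Compound 1 `CCCSc1nc(C(C)c2c(F)cccc2Cl)c(C)c(=O)[nH]1` gives > 1500 nM, which is a limit. Compound 2 `CCc1c(C(C)c2c(F)cccc2Cl)nc(SC(C)C)[nH]c1=O` gives > 3000 nM, also a limit. Compound 3 `CCc1c(C(C)c2c(F)cccc2F)nc(SC(C)C)[nH]c1=O` gives > 3000 nM, again a limit, so no exact number fixes where it stands. Compound 4 `CCc1c(C(C)c2c(F)cccc2F)nc(SC2CCCC2)[nH]c1=O` differs from it in one place: cyclopentyl in place of isopropyl on a sulfur. For the measured compounds named here, the only measured step, a step that the two limits leave unreadable from compound 2 to compound 3, is a fluoro in place of chloro on an aromatic carbon, and it offers no size to carry over. No step beyond the scatter is therefore expected, and no direction is favoured. The expected step is a step that the limit leaves unreadable from compound 3 to compound 4. Compound 4 is estimated at 3500 nM, with an expected range of 1200 nM to 12000 nM.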

Compound 4, half-maximal cytotoxic concentration: > 3000 nM
Compound 4: a limit, no number; the forecaster's own chance of this, stated with the estimate: 70%; the middle value does not contradict the limit.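

In this assay, compound 3 and compound 4 each stand only at a limit, so no step can be read between them. The compounds shown leave open where the true tolerated concentration of any of them lies.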